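This account rests on a few compounds, and the source may have more. Where it says the series, first, only, none or still open, it means among the compounds named here.

Two measured compounds share the core that compound 3 will also carry. In an ADME assay on RAW264.7 cells (Mus musculus) for cytotoxicity, read by MTT assay, with a stated time of 24 h (on this read-out lower numbers stand for higher toxicity in this test and higher numbers for lower toxicity in this test), compound 1 `COc1ccccc1C(=O)Nc1ccc(I)cc1F` gives > 40000 nM, a limit of the assay rather than a number. Compound 2 `O=C(Nc1ccc(I)cc1F)c1ccccc1` gives > 40000 nM in this assay, again a limit of the assay. The step that the two limits leave unreadable from compound 1 to compound 2 is unreadable because the limit of > 40000 nM in this assay, at which 2 of the 2 values shown sit, holds both values. On the numbers shown, compound 2 stands at that limit, with no measured step around it that has a readable size.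

Compound 3 `COc1ccc(C(=O)Nc2ccc(I)cc2F)cc1` differs from compound 2 by methoxy in place of hydrogen on an aromatic carbon. Going by the values given here, the only measured step, a step that the two limits leave unreadable from compound 1 to compound 2, is the reverse kind of change on the same ring, and its size cannot be read. Among the compounds with values here, no measured step therefore tells how large a move to expect in this assay, in either direction. The expectation for compound 3 rests on the limit of > 40000 nM in this assay, at which 2 of the 2 values shown sit: a step of a number no higher from compound 2 to compound 3 (the limit leaves the size open) is expected, which amounts to no move beyond the scatter. Compound 3 is therefore expected to give about 40000 nM in this assay, in the range 20000 nM to 80000 nM, and most likely to come back as a limit once more.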

Compound 3, half-maximal cytotoxic concentration: 32800 nM
Compound 3: middle estimate off by 1.2-fold (0.09 log units), on the high side; measured number inside the range.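

With methoxy para to a large group, the series gives its first number that is not a limit: in this assay compound 3 gives 32800 nM. As far as these compounds go, the change from hydrogen to methoxy at this place is an at least 1.2-fold lower number from compound 2 to compound 3 (0.08 log units; that floor lies within the scatter), so what can be read is only a floor, and the true size of the step stays open, as compound 2 has no number of its own. This is still more than the earlier pair offered, since the step between compound 1 and compound 2, which has the same change in reverse at another place on that ring, cannot be read, and most of the series stays at one limit: the limit of > 40000 nM in this assay, at which 2 of the 3 values shown sit.

The compounds shown leave open how far compound 2 lies from compound 3 in this assay, and so whether methoxy at this place moves the number beyond the usual scatter at all. They also leave open what an amine, a carboxylic acid or a longer chain such as ethoxy would give at the same place on the shared core, and whether any of these would yield a number rather than a limit.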